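Trimethylphenyl for dichloromethylphenyl on a thiazole-based CRF1 series

The source may report more compounds than this note shows. Statements on the series, on what has been measured and on what is new or still open speak of the compounds shown alone.

Of the compounds shown here, two have been measured in an assay for displacement of a labelled ligand from corticotropin-releasing factor receptor 1 (Homo sapiens); on this read-out lower numbers stand for stronger inhibition and higher numbers for weaker inhibition. Compound 1 `CCCN(CC1CC1)C(=O)c1sc(Nc2c(C)cc(C)cc2C)nc1C` gives 2600 nM in this assay. Compound 2 `CCCN(Cc1sc(Nc2c(C)cc(Cl)cc2Cl)nc1C(F)(F)F)CC1CC1` gives 16 nM in this assay, the lowest number of the two, and its gap to compound 1 lies well beyond the usual scatter of repeated measurements. Compound 1 and compound 2 differ in more than one place, so no single structural change can be tied to that gap.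

Compound 3 `CCCN(Cc1sc(Nc2c(C)cc(C)cc2C)nc1C(F)(F)F)CC1CC1` has not yet been measured. It differs from compound 2 in exactly one place: 2,4,6-trimethylphenyl in place of 2,4-dichloro-6-methylphenyl on a nitrogen on an aromatic ring. The aryl group entering compound 3 is the same one carried by compound 1, while everything else in compound 3 stays as in compound 2.

Among the compounds with values here, no measured pair shows this change alone, so the size of the step is uncertain. A modest weakening is expected, with the step from compound 2 to compound 3 estimated at a 2.8-fold higher number from compound 2 to compound 3 (0.45 log units; beyond the scatter). Compound 3 is therefore expected to give about 45 nM in this assay, most likely between 12 nM and 200 nM.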

Compound 3, inhibition constant: 60 nM
For compound 3 the middle estimate is 1.3-fold (0.12 log units) below the measured one; low and high end bracket the measured number.
By their numbers in this assay, from the lowest: compound 2; then compound 3; then compound 1.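

In this assay the exchange of 2,4-dichloro-6-methylphenyl for 2,4,6-trimethylphenyl on a nitrogen on an aromatic ring gives a 3.8-fold higher number from compound 2 to compound 3 (0.57 log units; beyond the scatter), a modest step, but one that lies beyond the scatter. Within the data shown here, this is the first single-place comparison, and it shows that this position responds to the exchange even though both groups hold 9 heavy atoms and neither carries a hydrogen-bond donor or acceptor, the difference being that carbon stands where the two chlorine atoms stood. No measurement is available that explains this step.

The two chlorine atoms are exchanged together here, so the compounds shown leave open how much of the step belongs to each, which a 2-chloro-4,6-dimethylphenyl or 4-chloro-2,6-dimethylphenyl group on the same nitrogen could help to separate. Also open, from the compounds shown here alone, is whether other groups at this position, such as 2,4-dimethoxy-6-methylphenyl or 2,4-dibromo-6-methylphenyl, would give lower or higher numbers than the two aryl groups compared here.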